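Swapping a Methyl for Two Chlorines on the Benzyl Ether

The compounds below may be only part of what the source reports. "The series", "measured", "known", "first", "only" and "open" are said of these compounds alone.

Among the compounds with values here, compound 2 `Cc1ccc(COc2ccc(C(=O)NC(=O)Nc3ccc(C)c(-c4nc5ccccc5[nH]4)c3)cc2)cc1` is the only compound with a numbered result in a functional assay on MGC-803 cells (Homo sapiens) for inhibition, read by MTT assay, with a stated time of 48 h (a lower number here means a stronger inhibitor, a higher number a weaker inhibitor), where compound 2 gives 4250 nM. Compound 1 `Cc1ccc(NC(=O)NC(=O)c2ccc(OCc3cccc(Cl)c3Cl)cc2)cc1-c1nc2ccccc2[nH]1` reaches only a limit in this assay, giving > 100000 nM. Compound 3 `Cc1ccc(NC(=O)NC(=O)c2ccc(OCc3ccc(Cl)c(Cl)c3)cc2)cc1-c1nc2ccccc2[nH]1` has not yet been measured; it differs from compound 2 in one place: 3,4-dichlorophenyl in place of 4-methylphenyl on a saturated chain carbon bound to an oxygen on an aromatic ring. A single measured step bears on this change. That step swapped a 2,3-dichlorophenyl for a 4-methylphenyl at the same place and gave an at least 23-fold lower number from compound 1 to compound 2 (1.37 log units; beyond the scatter), a large drop, with the starting value being a limit (the limit of > 100000 nM in this assay, at which 1 of the 2 values shown sits). Compound 3 reverses that direction by returning to a dichlorophenyl, so a clearly higher number, meaning weaker inhibition, is expected, with a fair chance that only a limit is recorded. The expected step is a 9.4-fold higher number from compound 2 to compound 3 (0.97 log units; beyond the scatter). For compound 3 the estimate is 40000 nM, expected to fall between 8000 nM and 200000 nM.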

Compound 3, half-maximal inhibitory concentration: 6080 nM
The estimate for compound 3 lay 6.6-fold (0.82 log units) above the measured number, outside the stated range (below it).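

In this assay, putting 3,4-dichlorophenyl in place of 4-methylphenyl gives a 1.4-fold higher number from compound 2 to compound 3 (0.16 log units; within the scatter), so two chlorines on this ring do not by themselves bring the loss seen earlier. The placing of the chlorines is what matters among the compounds shown, since 3,4-dichlorophenyl in place of 2,3-dichlorophenyl gives an at least 16-fold lower number from compound 1 to compound 3 (1.21 log units; beyond the scatter). Compound 1 stands at a limit, not a number: the limit of > 100000 nM in this assay, at which 1 of the 3 values shown sits.

Only three groups at this place are shown, so it stays open whether the poor result belongs to 2,3-dichlorophenyl alone or extends to other groups with a chlorine on that side of the ring. A plain phenyl, a 4-chlorophenyl, a pyridine ring or a longer chain in place of the single saturated carbon would show how much this place tolerates.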